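The source may report more compounds than this note shows. Statements on the series, on what has been measured and on what is new or still open speak of the compounds shown alone.

Working notes on the series, followed in a functional assay on MCF7 cells (Homo sapiens) for antiproliferative activity, read by sulforhodamine B assay, with a stated time of 72 h; on this read-out lower numbers stand for stronger inhibition and higher numbers for weaker inhibition.

Compound 1 `COc1c(OC(C)C)cc2occ(-c3csc4ccccc34)c(=O)c2c1O` is measured there and gives only a limit, > 10000 nM. Compound 2 `COc1c(O)cc2occ(-c3csc4ccccc34)c(=O)c2c1O` likewise gives only a limit, > 10000 nM. The change between these two is hydrogen in place of isopropyl on an oxygen on an aromatic ring, and the step that the two limits leave unreadable from compound 1 to compound 2 is one that the two limits leave unreadable. Compound 3 `COc1c(OC(C)C)cc2c(c1OC(C)C)C(=O)/C(=C/c1csc3ccccc13)O2` carries a different core; how the core of compound 3 differs from the core of compound 1 is not broken down here. Compound 3 also gives only a limit in this assay, > 10000 nM. All three measured values therefore sit at the limit of > 10000 nM in this assay, at which 3 of the 3 values shown sit.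

Compound 4 `COc1c(OC(C)C)cc2c(c1O)C(=O)/C(=C/c1csc3ccccc13)O2` is not yet measured. Among the compounds with values here, it differs from compound 3 by hydrogen in place of isopropyl on an oxygen on an aromatic ring, which is the same change, at the same place, as the one made from compound 1 to compound 2. Compound 4 is expected to remain at the limit, since the same change left compound 1 and compound 2 both at the limit of > 10000 nM in this assay, at which 3 of the 3 values shown sit. The step that the limit leaves unreadable from compound 3 to compound 4 is accordingly estimated as small. Compound 4 is estimated at 15000 nM, with the likely range running from 5000 nM to 50000 nM.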

Compound 4, half-maximal inhibitory concentration: > 10000 nM
Compound 4: a limit, no number; the forecaster's own chance of this, stated with the estimate: 85%; the middle value is on the limit's open side.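

Compound 3 and compound 4 each give only a limit in this assay, so no step can be read between them, and every value shown stands the same way: the limit of > 10000 nM in this assay, at which 4 of the 4 values shown sit.

The compounds shown leave open whether either core, with isopropoxy or hydroxy, gives a measurable inhibition value in this assay, and how the two cores compare.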